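A few compounds are considered here, and "the series" means these few. Any claim that something is new, unique, unknown or untested is made for them only; others in the source may bear on it.

In a functional assay on SW982 cells (Homo sapiens) for inhibition, read by MTT assay, with a stated time of 72 h (a lower number here means a stronger inhibitor, a higher number a weaker inhibitor), compound 1 `COc1ccc(C(=O)/C=C/c2cc(OC)c(OC)cc2OC)cc1` gives 60500 nM. Going by the values given here, only one other compound in this small set has a true number: compound 3 `COc1cc(OC)c(OC)cc1/C=C/C(=O)c1cc(Cc2ccccc2)cc(Cc2ccccc2)c1`, at 69900 nM. These two values lie within the usual scatter of each other, so repeat measurements could not be expected to separate them, and neither can be ranked ahead of the other. Compound 2 `COc1cc(OC)c(-c2cc(=O)c3ccc(O)cc3o2)cc1OC` has only a limit, > 150000 nM, and this is not a measured number.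

The next compound, not yet measured, is compound 4 `COc1cc(OC)c(OC)cc1/C=C/C(=O)c1cc(Cl)ccc1O`. It has 5-chloro-2-hydroxyphenyl in place of 4-methoxyphenyl on a carbonyl carbon. The rest of compound 1 stays the same.

Among the compounds with values here, no measured pair here isolates this exchange, so the data give no direct size for the step. The closest guide is that compound 1 at 60500 nM and compound 3 at 69900 nM show no separation beyond the scatter. No large move is therefore assumed in this assay, and the expectation is for no change beyond the scatter. The estimated step is a 1.2-fold lower number from compound 1 to compound 4 (0.08 log units; within the scatter).

For compound 4, the expected value is 50000 nM. The estimated range for compound 4 runs from 17000 nM to 140000 nM.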

Compound 4, half-maximal inhibitory concentration: > 150000 nM
Compound 4 ended at the assay's limit; the forecaster's own chance of this, stated with the estimate: 15%; at least 3.0-fold (0.47 log units) between middle value and limit.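

Going by these compounds alone, on the carbonyl carbon, the group is not freely exchangeable in this assay: 5-chloro-2-hydroxyphenyl in place of 4-methoxyphenyl gives an at least 2.4-fold higher number from compound 1 to compound 4 (0.39 log units; beyond the scatter), the first step in this set that can be read between compounds differing in one place. The two groups have the same number of heavy atoms and each holds one six-membered aromatic ring of carbon only. What differs is what the ring carries, with a chlorine and a hydroxy group in place of a methoxy group, and with that a hydrogen-bond donor that 4-methoxyphenyl lacks. The full size of the step remains unknown, and the printed figure is only its smallest possible size, because the result for compound 4 is a limit and not a number: the limit of > 150000 nM in this assay, at which 2 of the 4 values shown sit.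

The chlorine and the hydroxy group enter together here, so the compounds shown cannot tell which of them goes with the weaker result. As far as these compounds go, how the number would respond to an amine or a carboxylic acid on this ring also remains open.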